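Cytotoxicity notes: a second aryl fluoro analogue

A few compounds are considered here, and "the series" means these few. Any claim that something is new, unique, unknown or untested is made for them only; others in the source may bear on it.

Measured so far:
compound 1 `COc1ccc(-n2cc(CNCCN3CCN(C)CC3)c(-c3ccccc3C)n2)cc1` — in an ADME assay on Huh-7 cells (Homo sapiens) for cytotoxicity (a higher number here means that more compound is tolerated, a lower number that less compound is tolerated), compound 1 gives > 20000 nM, a limit of the assay.
compound 2 `Cc1ccccc1-c1nn(-c2ccc(F)cc2)cc1CNCCN1CCN(C)CC1` — in this assay compound 2 gives > 20000 nM, likewise a limit.

Within the data shown here, compound 2 therefore stands at the assay limit, and the one further value shown is a limit as well. Among the measured compounds shown here, the only measured step, a step that the two limits leave unreadable from compound 1 to compound 2 (fluoro in place of methoxy on an aromatic carbon), cannot be sized because both of its ends sit at the limit of > 20000 nM in this assay, at which 2 of the 2 values shown sit.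

Compound 3 `Cc1ccccc1-c1nn(-c2ccc(F)cc2F)cc1CNCCN1CCN(C)CC1` differs from compound 2 by fluoro in place of hydrogen on an aromatic carbon. For the measured compounds named here, the one measured step bears on it only in that neither end left the limit, so no step beyond the scatter is expected in this assay, in either direction. Compound 3 is expected to give 30000 nM (range 15000 nM to 80000 nM), again most likely reported as a limit. The expected step is a step that the limit leaves unreadable from compound 2 to compound 3.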

Compound 3, half-maximal cytotoxic concentration: > 20000 nM
Compound 3 was reported as a limit; the forecaster's own chance of this, stated with the estimate: 80%; the middle value lies beyond the limit too.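

Compound 3 also sits at a limit, so no step among compound 1, compound 2 and compound 3 can be read in this assay: the limit of > 20000 nM in this assay, at which 3 of the 3 values shown sit.

The compounds shown leave open how much compound each tolerates beyond that limit, and whether either substitution changes cytotoxicity at all.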